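A few compounds are considered here, and "the series" means these few. Any claim that something is new, unique, unknown or untested is made for them only; others in the source may bear on it.

Compound 3 `Cc1ccc(OC(C)(C)C2OCC(C/C=C\CCC(=O)O)C(c3cccnc3)O2)cc1` stands second highest of the three numbers in a functional assay for inhibition, with Homo sapiens as the target (on this read-out lower numbers stand for tighter binding and higher numbers for weaker binding), where compound 3 gives 631 nM. Its nearest neighbour is compound 1 `O=C(O)CC/C=C\CC1COC(c2ccc3ccccc3c2)OC1c1cccnc1`, for which this assay gives 1780 nM; furthest away is compound 2 `CSc1ccc(OC(C)(C)C2OCC(C/C=C\CCC(=O)O)C(c3cccnc3)O2)c([N+](=O)[O-])c1`, which gives 4.47 nM in this assay. Among the compounds with values here, the one measured step that touches the same part of the molecule is a 140-fold higher number from compound 2 to compound 3 (2.15 log units; beyond the scatter), a large move from one aryl group to another on the oxygen on the saturated carbon.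

Compound 4 `CC(C)(C1OCC(C/C=C\CCC(=O)O)C(c2cccnc2)O1)S(=O)(=O)c1ccccc1` differs from compound 3 by phenylsulfonyl in place of 4-methylphenoxy on a saturated chain carbon bound to two saturated chain carbons and a saturated ring carbon. Here the oxygen that linked the aryl group is gone and a phenylsulfonyl sits directly on the saturated chain carbon; no measured pair shows this kind of exchange, so the step from compound 2 to compound 3 bears on it only loosely, telling that the group at this place can shift this assay by a great deal in either direction. With no closer guide, the estimate for compound 4 is a step of a 1.3-fold higher number from compound 3 to compound 4 (0.10 log units; within the scatter), small and within a wide range. Compound 4 is therefore expected to give about 800 nM in this assay, with the likely span running from 150 nM to 4000 nM.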

Compound 4, dissociation constant: 3160 nM
Compound 4: the middle estimate sits 4.0-fold (0.60 log units) below what was measured; the measured number falls inside the stated range.
By their numbers in this assay, from the lowest: compound 2; then compound 3; then compounds 1 and 4 (each within the scatter of the next).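

In this assay, phenylsulfonyl in place of 4-methylphenoxy on the saturated chain carbon gives a 5.0-fold higher number from compound 3 to compound 4 (0.70 log units; beyond the scatter) in the weaker-binding direction, a modest step but one beyond the scatter. Within the data shown here, the earlier step at this place, a 140-fold higher number from compound 2 to compound 3 (2.15 log units; beyond the scatter), exchanged one aryl group for another and kept the oxygen on the saturated carbon, whereas this one removes that oxygen and puts a sulfonyl in the link, so it is the first measured sign that the link itself can be changed at this place with a modest move in the number. Nothing at hand accounts for this step.

Compound 4 differs from compound 3 in both the link and the methyl on the ring, so these compounds cannot say how much of the step belongs to each, and a plain phenoxy group or a 4-methylphenylsulfonyl group would be needed to separate them. They also leave open whether the nitro and methylthio groups of compound 2 would lower the number on a phenylsulfonyl ring as well, and how a phenylthio group or an amine link would read at this place.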